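Aminonicotinonitrile series: thiophene to phenyl at the pyridine

This account rests on a few compounds, and the source may have more. Where it says the series, first, only, none or still open, it means among the compounds named here.

Three compounds of this small set have been run in a functional assay on NCI-H522 cells (Homo sapiens) for inhibition, read by sulforhodamine B assay, with a stated time of 48 h; a lower number here means a stronger inhibitor of growth, a higher number a weaker inhibitor of growth. Compound 1 `COc1ccc(-c2cc(-c3cccn3C)c(C#N)c(=O)[nH]2)cc1OC` returns only a limit of the assay; in this assay compound 1 gives > 100000 nM. Compound 3 `COc1ccc(-c2cc(-c3cccn3C)c(C#N)c(N)n2)cc1OC` gives a number: in this assay compound 3 gives 40700 nM. Compound 2 `Cn1cccc1-c1cc(-c2cccs2)nc(N)c1C#N` stands at a limit as well; in this assay compound 2 gives > 100000 nM. No number is known for compound 2, and it shares its standing with another member of the set at the limit of > 100000 nM in this assay, at which 2 of the 3 values shown sit.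

The next compound, compound 4 `Cn1cccc1-c1cc(-c2ccccc2)nc(N)c1C#N`, differs from compound 2 in one place: phenyl in place of thiophen-2-yl on an aromatic carbon. For the measured compounds named here, no pair of measured compounds differing in a single place is available to size such a change. With compound 2 at a limit rather than a number, the step is expected to be none beyond the scatter, and a limit is again the most likely outcome. Compound 4 is expected to give 120000 nM in this assay, within a range of 40000 nM to 400000 nM, which amounts to an expected step that the limit leaves unreadable from compound 2 to compound 4.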

Compound 4, concentration for 50% growth inhibition: 61600 nM
Compound 4: the middle estimate sits 1.9-fold (0.29 log units) above what was measured; measured number inside the range.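

In this assay, for the compounds shown here, phenyl in place of thiophen-2-yl next to the ring nitrogen gives compound 4 a readable number, the first measured value at this position with the 1-methyl-1H-pyrrol-2-yl group and the amino group held constant. The change reads as an at least 1.6-fold lower number from compound 2 to compound 4 (0.21 log units; that floor lies within the scatter), so only a floor on the step is known, and that floor does not by itself show a change beyond the scatter. The true size of the step stays unknown because compound 2 stands at a limit and not at a number: the limit of > 100000 nM in this assay, at which 2 of the 4 values shown sit.

From the compounds shown here alone, what a pyridin-3-yl ring, or a phenyl carrying a chloro or a carboxylic acid group, would give at this position remains open. Also open, going by these compounds, is whether the amino group can be replaced by a methylamino or a morpholine group while compound 4 keeps a readable number.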